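A few compounds are considered here, and "the series" means these few. Any claim that something is new, unique, unknown or untested is made for them only; others in the source may bear on it.

Working notes on the oxalyl-type series sharing the core of compound 1 `O=C1C(=O)N(Cc2ccc(Cl)nc2)c2ccc(OC(F)(F)F)cc21`. In a functional assay on CHO cells for positive allosteric modulation of muscarinic acetylcholine receptor M5 (Homo sapiens), read by FLIPR and calcium flux, with a stated time of 1 h (a lower number here means that less compound is needed, a higher number that more compound is needed for the effect), compound 1 gives 2400 nM. Compound 2 `COc1cccc(Oc2ccc(CN3C(=O)C(=O)c4cc(OC(F)(F)F)ccc43)cc2)n1`, which carries a (6-methoxypyridin-2-yl)oxy group on the benzyl arm, gives in this assay a value of 2200 nM; the gap between compound 2 and compound 1 lies within the usual scatter, so the two numbered values sit together. Compound 3 `O=C1C(=O)N(Cc2ccc(-c3cccnc3)cn2)c2ccc(OC(F)(F)F)cc21` reaches in this assay only > 30000 nM, which is a limit of the assay and not a number; this is the limit of > 30000 nM in this assay, at which 1 of the 3 values shown sits.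

Compound 4 `O=C1C(=O)N(Cc2ccc(Oc3cccc(F)n3)cc2)c2ccc(OC(F)(F)F)cc21` is not yet measured. Its difference from compound 2 is fluoro in place of methoxy on an aromatic carbon: the change is fluoro in place of methoxy, cut one bond further out (6-methoxypyridin-2-yl)oxy to (6-fluoropyridin-2-yl)oxy, on an aromatic carbon of a six-membered aromatic ring with one nitrogen, next to the ring nitrogen and meta to a large group. Within the data shown here, no measured pair isolates this exchange, so no measured step can guide the size. The small swap at the outer ring is expected to leave this assay within the scatter, with a step of a 1.1-fold higher number from compound 2 to compound 4 (0.06 log units; within the scatter). Compound 4 is therefore estimated at 2500 nM, in the range 1000 nM to 7000 nM.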

Compound 4, half-maximal effective concentration: 1500 nM
The estimate for compound 4 lay 1.7-fold (0.22 log units) above the measured number, and the stated range covers the measured number.
By their numbers in this assay, from the lowest: compounds 4, 2 and 1 (each within the scatter of the next). At a limit, above all of these: compound 3.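

In this assay, among these compounds, fluoro in place of methoxy on this aromatic carbon, next to the ring nitrogen, gives a 1.5-fold lower number from compound 2 to compound 4 (0.17 log units; within the scatter), and this is the first measured pair that isolates one change on the outer ring. At this position the two groups cannot be told apart in this read-out: going from methoxy to fluoro takes away a heavy atom and the hydrogen-bond acceptor counted for methoxy, yet the step stays within the scatter, so the (6-fluoropyridin-2-yl)oxy and (6-methoxypyridin-2-yl)oxy arms sit together. Nothing measured in the series bears on a cause for this step.

Among the compounds shown here, what an amine, a nitrile or a longer chain such as ethoxy would do on the same aromatic carbon remains open, since methoxy and fluoro are the only two groups compared there. A single pair also leaves open whether the same exchange would stay within the scatter at another carbon of the outer ring or on a different arm of the shared core.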